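The compounds below may be only part of what the source reports. "The series", "measured", "known", "first", "only" and "open" are said of these compounds alone.

Measured compounds in this series:
compound 1 `Cc1nc(C)n(CC(=O)N2CCN(c3sc(C(F)(F)F)nc3-c3cnc(OC(C)C)nc3)C[C@H]2C)n1` — 216 nM
compound 2 `Cc1ncc(-c2nc(C(F)(F)F)sc2N2CCN(C(=O)Cn3nc(C)nc3C)[C@H](C)C2)cn1` — 610 nM
compound 3 `CCc1ncc(-c2nc(C(F)(F)F)sc2N2CCN(C(=O)Cn3nc(C)nc3C)[C@H](C)C2)cn1` — 567 nM

All three values come from an assay on blood for inhibition of C-X-C chemokine receptor type 3 (Homo sapiens), with a stated time of 30 min; on this read-out lower numbers stand for stronger inhibition and higher numbers for weaker inhibition. Compound 3 sits second highest of the three numbers: its nearest neighbour is compound 2, whose number lies within the scatter of it, and its furthest is compound 1, which stands a 2.6-fold higher number from compound 1 to compound 3 (0.42 log units; beyond the scatter). The two alkyl analogues, compound 2 and compound 3, are not distinguishable from each other, since a 1.1-fold lower number from compound 2 to compound 3 (0.03 log units; within the scatter).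

The next compound, compound 4 `Cc1nc(C)n(CC(=O)N2CCN(c3sc(C(F)(F)F)nc3-c3cnc(C4CC4)nc3)C[C@H]2C)n1`, has not been measured in this assay. Its change from compound 3 is cyclopropyl in place of ethyl on an aromatic carbon. The step that bears most directly on it is the one within the same small-alkyl set: a 1.1-fold lower number from compound 2 to compound 3 (0.03 log units; within the scatter). The other two steps, a 2.8-fold higher number from compound 1 to compound 2 (0.45 log units; beyond the scatter) and a 2.6-fold higher number from compound 1 to compound 3 (0.42 log units; beyond the scatter), show that the isopropoxy group of compound 1 gives a lower number than either alkyl, but compound 4 does not recover that group. Swapping one alkyl for another has so far produced nothing beyond the scatter, so a step within the scatter is expected here as well: a 1.1-fold lower number from compound 3 to compound 4 (0.05 log units; within the scatter).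

For compound 4 the estimate in this assay is 500 nM, with a range of 250 nM to 1000 nM.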

Compound 4, half-maximal inhibitory concentration: 674 nM
Beside the measured number, compound 4's estimate is 1.3-fold (0.13 log units) below it, and the stated range covers the measured number.
By their numbers in this assay, from the lowest: compound 1; then compounds 3, 2 and 4 (each within the scatter of the next).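

In this assay, the carbon between two ring nitrogen atoms now carries a small ring as well as open alkyl groups, and the three-membered ring of cyclopropyl makes no readable difference against ethyl (a 1.2-fold higher number from compound 3 to compound 4 (0.08 log units; within the scatter)) or against methyl (a 1.1-fold higher number from compound 2 to compound 4 (0.04 log units; within the scatter)). Compounds 2, 3 and 4 therefore form one group at this position, with no order among them, even though the substituent changes from a chain to a ring of carbon only. The gap to the isopropoxy group of compound 1 also holds for the ring (a 3.1-fold higher number from compound 1 to compound 4 (0.49 log units; beyond the scatter)), so all three carbon-only groups shown stand apart from it, and none of them goes against this; nothing at hand says what lies behind the gap.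

Still open, as far as these compounds go, is whether the lower number of compound 1 goes with the ether oxygen or with the branched chain, a question that a methoxy group and an isopropyl group at this carbon would separate. Also open, from the compounds shown here alone, is how an amine such as dimethylamino would read at this place.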